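Trimethoxybenzoyl pyrrole series: aryl swap on the five-membered ring

A few compounds are considered here, and "the series" means these few. Any claim that something is new, unique, unknown or untested is made for them only; others in the source may bear on it.

Of the compounds shown here, two carry numbers so far. Compound 1 `COc1cc(C(=O)c2cn(-c3ccccc3)cc2-c2ccccc2Cl)cc(OC)c1OC` gives 76 nM in a functional assay on MCF7 cells (Homo sapiens) for cytotoxicity, read by MTT assay, with a stated time of 96 h; on this read-out lower numbers stand for stronger inhibition and higher numbers for weaker inhibition. Among the compounds with values here, compound 2 `COc1cc(C(=O)c2cn(-c3cccc(C)c3)cc2-c2ccccc2Cl)cc(OC)c1OC` gives 420 nM in this assay, the highest of the two numbers; its only neighbour is compound 1, and the step of a 5.5-fold higher number from compound 1 to compound 2 (0.74 log units; beyond the scatter) separates them.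

Compound 3 `COc1cc(C(=O)c2cn(-c3cccc(C)c3)cc2-c2ccc(N)cc2)cc(OC)c1OC` has not yet been measured in this assay. It differs from compound 2 as follows: 4-aminophenyl in place of 2-chlorophenyl on an aromatic carbon.

Within the data shown here, the single measured step, a 5.5-fold higher number from compound 1 to compound 2 (0.74 log units; beyond the scatter), concerns a methyl in place of hydrogen on the 3-methylphenyl group and says nothing about exchanging the ring that sits next to the ring atom that bears a large group. Among the measured compounds shown here, no measured pair bears on a 4-aminophenyl in place of 2-chlorophenyl, so neither the direction nor the size of the change can be read from the numbers at hand.

For the measured compounds named here, with no anchoring step, compound 3 is expected to land near compound 2, at an estimated 700 nM in this assay, within a wide range from 120 nM to 4500 nM; the step this estimate implies is a 1.7-fold higher number from compound 2 to compound 3 (0.22 log units; within the scatter), and a result on either side of the scatter would not surprise.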

Compound 3, half-maximal inhibitory concentration: 18 nM
Compound 3: middle estimate off by 39-fold (1.59 log units), on the high side; measured number below the stated range.
By their numbers in this assay, from the lowest: compound 3; then compound 1; then compound 2.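

In this assay, the group on this aromatic carbon of the five-membered aromatic ring with 1 nitrogen strongly affects the read-out: a 23-fold lower number from compound 2 to compound 3 (1.37 log units; beyond the scatter) is a larger step than the only earlier one, a 5.5-fold higher number from compound 1 to compound 2 (0.74 log units; beyond the scatter), which concerned a methyl in place of hydrogen. The exchange keeps 7 heavy atoms and a six-membered aromatic ring of carbon only in the group, so a large change in the number arises without a change in either count, while chlorine leaves and 4-aminophenyl brings 1 hydrogen-bond donor and 1 hydrogen-bond acceptor. No measurement at hand accounts for the size of this step.

The single exchange removes the chlorine and introduces the amine together, so the compounds shown cannot separate the two contributions; an unsubstituted phenyl at this position, or a hydroxyl or dimethylamino group in place of the amine, would help to do so. Also open, as far as these compounds go, is whether the methyl step from the earlier pair carries over when 4-aminophenyl occupies this position, which a phenyl in place of the 3-methylphenyl group alongside 4-aminophenyl would test.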